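A few compounds are considered here, and "the series" means these few. Any claim that something is new, unique, unknown or untested is made for them only; others in the source may bear on it.

Measured in a functional assay on HCT-116 cells (Homo sapiens) for antiproliferative activity, read by MTT assay, with a stated time of 48 h; a lower number here means a stronger inhibitor, a higher number a weaker inhibitor:
- Compound 1 `CCCC(CCO)n1cnc2c(Cl)ncnc21`: > 50000 nM (a limit of the assay)
- Compound 2 `CCCCCCCCCC(CCO)n1cnc2c(Cl)ncnc21`: 890 nM
- Compound 3 `CCCCCCCCCC(CCO)n1cnc2c(N(C)C)ncnc21`: 9810 nM

Compound 2 gives the lower of the two actual numbers, at 890 nM. Compound 3 is its nearest neighbour, an 11-fold higher number from compound 2 to compound 3 (1.04 log units; beyond the scatter). The other comparison, an at least 56-fold lower number from compound 1 to compound 2 (1.74 log units; beyond the scatter), rests on a limit: the limit of > 50000 nM in this assay, at which 1 of the 3 values shown sits.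

Compound 4 `C=C(CO)C(CCCCCCCCC)n1cnc2c(Cl)ncnc21` has 1-(hydroxymethyl)ethenyl in place of 2-hydroxyethyl on a saturated chain carbon bound to an aromatic nitrogen and a saturated chain carbon. Compound 4 keeps the chloro group and the long chain of compound 2, the two features changed in the measured steps. Those large steps therefore bear on it only indirectly, and neither tests this exchange. No step beyond the scatter is expected in this assay, and no direction can be favoured with confidence.

The expected change is a 1.3-fold higher number from compound 2 to compound 4 (0.13 log units; within the scatter). The estimate for compound 4 is 1200 nM, with an expected range of 300 nM to 5000 nM.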

Compound 4, half-maximal inhibitory concentration: > 50000 nM
Compound 4 ended at the assay's limit; the forecaster's own chance of this, stated with the estimate: 5%; at least 41-fold (1.61 log units) between middle value and limit.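

In this assay, this position is not a free place for change: 1-(hydroxymethyl)ethenyl in place of 2-hydroxyethyl gives an at least 56-fold higher number from compound 2 to compound 4 (1.74 log units; beyond the scatter). The earlier steps shown here varied the chain length and the chloro group, whereas this step shows that keeping both does not preserve the number of compound 2 once the group at this position is exchanged. The value of compound 4, > 50000 nM, is a limit of the assay, so the step has a lower bound only: the limit of > 50000 nM in this assay, at which 2 of the 4 values shown sit.

The exchange adds a carbon and a double bond together, so the compounds shown do not say which of the two goes with the loss; 1-(hydroxymethyl)ethyl, the saturated counterpart, would separate them. From the compounds shown here alone, whether the hydroxyl itself is needed at this position also stays open, and an amine in its place would bear on that.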